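The compounds below may be only part of what the source reports. "The series", "measured", "known", "first", "only" and "open" are said of these compounds alone.

Measured compounds:
- compound 1, `CCCCCc1c(C(C)C)nc(C(C)C)c(CO)c1-c1ccc(CC)cc1`: 42%
- compound 2, `CCCCCc1c(C(C)C)nc(C(C)C)c(CO)c1-c1cccc(Cl)c1`: 49%

Both compounds share one core and differ only in the aryl group on an aromatic carbon. In an assay on CHO cells for inhibition of Glucagon receptor (Homo sapiens), tested at 20 uM (on this read-out lower numbers stand for less inhibition and higher numbers for more inhibition at the one concentration tested (going by the name of the read-out)), compound 1 gives 42% and compound 2 gives 49%; the step of a number 7 percentage points higher from compound 1 to compound 2 (within the scatter) does not separate the two. Compound 2 therefore stands highest of the two numbers, but the nearest number, that of compound 1, lies within the scatter, so no order between them can be claimed.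

The next compound, compound 3, `CCCCCc1c(C(C)C)nc(C(C)C)c(CO)c1-c1cccc(C)c1`, is not yet measured in this assay. It differs from compound 2 by methyl in place of chloro on an aromatic carbon. Among the measured compounds shown here, the only measured step, a number 7 percentage points higher from compound 1 to compound 2 (within the scatter), swaps the whole aryl substitution pattern and stays within the scatter; no step that exchanges chloro for methyl at this position has been measured. With a single small-group exchange at an unchanged position, no step beyond the scatter is expected, so compound 3 is estimated at a number 4 percentage points lower from compound 2 to compound 3 (within the scatter) relative to compound 2. Compound 3 is expected to give about 45%, within the range 30% to 60%.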

Compound 3, a percentage reported as inhibition, at one concentration (the size of the read-out at that concentration, not a potency): 46%
Beside the measured number, compound 3's estimate is 1 percentage points below it, within the range that was stated.
By their numbers in this assay, from the lowest: compounds 1, 3 and 2 (each within the scatter of the next).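

In this assay the direct exchange of chloro for methyl on an aromatic carbon, meta to a large group, gives a number 3 percentage points lower from compound 2 to compound 3 (within the scatter) and so does not separate these two groups, which was not shown by the earlier compounds, where no such exchange could be read. The wider change of 3-methylphenyl in place of 4-ethylphenyl gives a number 4 percentage points higher from compound 1 to compound 3 (within the scatter) and likewise stays within the scatter, so all three aryl groups seen so far remain indistinguishable on this assay and the read-out at this single concentration gives no ranking among them. No independent evidence bears on this result.

Open, from the compounds shown here alone, is whether a group of a different kind on the same aromatic carbon, such as an amine, a carboxylic acid or a longer chain, would give a step beyond the scatter in this assay where chloro and methyl do not. Also open, going by these compounds, is how far the other substituents on the shared core contribute to the read-out, as all three compounds carry them unchanged.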